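Replacing the Hydroxy of Compound 1 with Aminoamino

A few compounds are considered here, and "the series" means these few. Any claim that something is new, unique, unknown or untested is made for them only; others in the source may bear on it.

In a functional assay on SF-268 cells (Homo sapiens) for cytotoxicity, read by MTT assay, with a stated time of 3 days (a higher number here means a weaker inhibitor, a lower number a stronger inhibitor), compound 1 `N#Cc1c(O)nc(SCc2nc3ccccc3[nH]2)nc1-c1ccccc1` gives 3.2 nM, level with compound 2 `N#Cc1c(Cl)nc(SCc2nc3ccccc3[nH]2)nc1-c1ccccc1` at 3.2 nM. Compound 3 `N#Cc1c(NN)nc(SCc2nc3ccccc3[nH]2)nc1-c1ccccc1` carries aminoamino in place of hydroxy on an aromatic carbon, ortho to a cyano group (aminoamino in place of hydroxy on an aromatic carbon). Among the measured compounds shown here, only one measured step bears on this change: chloro in place of hydroxy on an aromatic carbon gave no change at the digits printed from compound 1 to compound 2 (within the scatter). That single step gives little to go on, so the expected result in this assay is no change at the digits printed from compound 1 to compound 3 (within the scatter), with no shift beyond the scatter foreseen. For compound 3 the estimated value is 3.2 nM, within an expected range of 0.8 nM to 13 nM.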

Compound 3, half-maximal inhibitory concentration: 2.77 nM
For compound 3 the middle estimate is 1.2-fold (0.06 log units) above the measured one, within the range that was stated.
By their numbers in this assay, from the lowest: compounds 3, 1 and 2 (each within the scatter of the next).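

In this assay, the position ortho to a cyano group now holds a third group with no shift beyond the scatter: aminoamino in place of hydroxy gives a 1.2-fold lower number from compound 1 to compound 3 (0.06 log units; within the scatter), and aminoamino in place of chloro gives a 1.2-fold lower number from compound 2 to compound 3 (0.06 log units; within the scatter). The level therefore holds across hydroxy, chloro and aminoamino, including the change from 1 heavy atom to 2 heavy atoms. No evidence is available to explain this. As far as these compounds go, whether a morpholine, a carboxylic acid or a longer amine chain at this position would hold the same level remains open.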